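Replacing the 2,4-dichlorophenyl group of compound 2

The compounds below may be only part of what the source reports. "The series", "measured", "known", "first", "only" and "open" are said of these compounds alone.

Compound 1 `COc1ccccc1/C=C1\CCC/C(=C\c2ccc(OC)c(OC)c2)C1=O` gives 7800 nM
Compound 2 `COc1ccc(/C=C2\CCC/C(=C\c3ccc(Cl)cc3Cl)C2=O)cc1OC` gives 10300 nM

In a functional assay on SW-620 cells (Homo sapiens) for cytotoxicity, read by MTT assay, with a stated time of 72 h (on this read-out lower numbers stand for stronger inhibition and higher numbers for weaker inhibition), compound 2 lies within the scatter of compound 1, so the two cannot be ranked. Compound 3 `COc1ccc(/C=C2\CCC/C(=C\c3ccc(O)c(Cl)c3)C2=O)cc1OC` differs from compound 2 by 3-chloro-4-hydroxyphenyl in place of 2,4-dichlorophenyl on a double-bonded chain carbon bound to a double-bonded ring carbon in one place: 3-chloro-4-hydroxyphenyl in place of 2,4-dichlorophenyl on a double-bonded chain carbon bound to a double-bonded ring carbon. Within the data shown here, the one measured change at that place is a 1.3-fold higher number from compound 1 to compound 2 (0.12 log units; within the scatter) and it gives no sign of a larger shift, although neither measured compound carries the entering group. No step beyond the scatter is therefore expected in this assay for this change. The estimate implies an expected 1.3-fold lower number from compound 2 to compound 3 (0.11 log units; within the scatter) and nothing more. The estimate for compound 3 is 8000 nM (expected range 3000 nM to 20000 nM).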

Compound 3, half-maximal inhibitory concentration: 7100 nM
Estimate against measurement, compound 3: 1.1-fold (0.05 log units) above, and the stated range covers the measured number.
By their numbers in this assay, from the lowest: compounds 3, 1 and 2 (each within the scatter of the next).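

In this assay the 3-chloro-4-hydroxyphenyl group gives a 1.5-fold lower number from compound 2 to compound 3 (0.16 log units; within the scatter) and also a 1.1-fold lower number from compound 1 to compound 3 (0.04 log units; within the scatter) when set on a double-bonded chain carbon bound to a double-bonded ring carbon, so neither step separates the compounds. This entering group carries a hydrogen-bond donor and a hydrogen-bond acceptor, which 2,4-dichlorophenyl lacks, yet compound 3 cannot be ranked against compound 1 or compound 2. Going by these compounds, whether an amine or a carboxylic acid at this place would give a step beyond the scatter stays open. No evidence at hand bears on this result.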